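Adding a ring methyl to the benzyl-bearing anilide

A few compounds are considered here, and "the series" means these few. Any claim that something is new, unique, unknown or untested is made for them only; others in the source may bear on it.

Of the compounds shown here, three from this series have been measured in an assay on isolated protein for inhibition of hexosaminidase D (Homo sapiens), tested at 10 uM; on this read-out lower numbers stand for less inhibition and higher numbers for more inhibition at the one concentration tested (going by the name of the read-out). Compound 1 `CC(=O)Nc1ncc(CN2CCN(CC(=O)Nc3ccccc3)CC2C)s1` gives 103%, compound 2 `CC(=O)Nc1ncc(CN2CCN(CC(=O)Nc3ccc(Cl)cc3)CC2C)s1` gives 92.4%, and compound 3 `CC(=O)Nc1ncc(CN2CCN(CC(=O)Nc3ccc(Cc4ccccc4)cc3)CC2)s1` gives 101%. Compound 3 thus stands among the three numbers with compound 1 as its nearest neighbour and compound 2 as its furthest, and both gaps lie within the usual scatter of the read-out. Among the compounds with values here, the one step recorded between two compounds differing in a single place, a number 10.6 percentage points lower from compound 1 to compound 2 (beyond the scatter), concerns a chloro group on the aromatic ring and does not touch the ring carbon altered here.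

Compound 4 `CC(=O)Nc1ncc(CN2CCN(CC(=O)Nc3ccc(Cc4ccccc4)cc3)CC2C)s1` differs from compound 3 in one place: methyl in place of hydrogen on a saturated ring carbon. Within the data shown here, no measured pair isolates this change, so no measured step bears on it directly; compound 1 and compound 2 carry the methyl, compound 3 does not, and all three values sit close together. In this assay compound 4 is therefore expected to show a number 2 percentage points lower from compound 3 to compound 4 (within the scatter), a change not beyond the scatter. The estimate for compound 4 is 99%, with a range from 87% to 108%.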

Compound 4, a percentage reported as inhibition, at one concentration (the size of the read-out at that concentration, not a potency): 107%
Estimate against measurement, compound 4: 8 percentage points below; the range from low to high includes it.
By their numbers in this assay, from the lowest: compounds 2, 3, 1 and 4 (each within the scatter of the next, the first and the last beyond it).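

In this assay, within the data shown here, the pair of compound 3 and compound 4 isolates methyl in place of hydrogen on this saturated ring carbon for the first time, and a number 6 percentage points higher from compound 3 to compound 4 (within the scatter) shows that the methyl does not separate the two compounds on this read-out. With the methyl present, benzyl in place of hydrogen gives a number 4 percentage points higher from compound 1 to compound 4 (within the scatter) and so also stays inside the scatter, while benzyl in place of chloro gives a number 14.6 percentage points higher from compound 2 to compound 4 (beyond the scatter) and is the only one of the three new steps that exceeds it. No evidence is available that accounts for these numbers.

Going by these compounds, it remains open whether an ethyl or a hydroxymethyl group on this ring carbon would leave the number unchanged. A single concentration also leaves open whether compound 3 and compound 4 differ in potency.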